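This account rests on a few compounds, and the source may have more. Where it says the series, first, only, none or still open, it means among the compounds named here.

Compound 1 `CC(C)c1cc2c(N/N=C\c3ccccn3)ncnc2s1`: 0.003 ug/mL
Compound 2 `CC(C)c1cc2c(N/N=C\c3cccnc3)ncnc2s1`: 0.889 ug/mL

In a functional assay on PC-6 cells (Homo sapiens) for antiproliferative activity (a higher number here means a weaker inhibitor, a lower number a stronger inhibitor), compound 1 gives 0.003 ug/mL, the lowest of the two numbers shown; its nearest neighbour is compound 2, which in this assay gives 0.889 ug/mL. Going by the values given here, the only step measured, a 300-fold higher number from compound 1 to compound 2 (2.47 log units; beyond the scatter), concerns the pyridyl group, not the alkyl side of the shared core.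

Compound 3 `CC(C)(C)c1cc2c(N/N=C\c3ccccn3)ncnc2s1` differs from compound 1 by methyl in place of hydrogen on a saturated chain carbon bound to an aromatic carbon and two saturated chain carbons; read one bond further out, it is isopropyl to tert-butyl. No measured step touches this position, so nothing shown bears directly on it. The pyridin-2-yl group that goes with the low number of compound 1 is kept. Compound 3 is therefore expected to show no step beyond the scatter, a 1.3-fold higher number from compound 1 to compound 3 (0.12 log units; within the scatter). Compound 3 is estimated at 0.004 ug/mL, with a range from 0.001 ug/mL to 0.03 ug/mL in this assay.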

Compound 3, half-maximal inhibitory concentration: 0.009 ug/mL
Estimate against measurement, compound 3: 2.3-fold (0.35 log units) below; low and high end bracket the measured number.
By their numbers in this assay, from the lowest: compound 1; then compound 3; then compound 2.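

In this assay, the alkyl side of the shared core now has a measured step of its own: going from isopropyl to tert-butyl gives a 3.0-fold higher number from compound 1 to compound 3 (0.48 log units; beyond the scatter). The position therefore tolerates the added methyl only with a modest loss, far smaller than the change on the pyridyl group, a 300-fold higher number from compound 1 to compound 2 (2.47 log units; beyond the scatter), and compound 3 still gives 0.009 ug/mL. Nothing measured here accounts for the loss seen with the added methyl.

The compounds shown leave open how an ethyl, a cyclopropyl or a longer chain would read in place of isopropyl, so a single step gives no trend across alkyl groups. They also leave open whether tert-butyl would give a step of similar size alongside pyridin-3-yl rather than pyridin-2-yl.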